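The compounds below may be only part of what the source reports. "The series", "measured", "known", "first", "only" and "open" are said of these compounds alone.

In an ADME assay on BJ cells (Homo sapiens), read by MTT assay, with a stated time of 72 h (on this read-out higher numbers stand for weaker inhibition and lower numbers for stronger inhibition), three related compounds have been measured. Compound 3 `CSc1ncnc2c1c(-c1cccs1)cn2[C@@H]1O[C@H](CO)[C@@H](O)[C@H]1O` gives 96900 nM, the higher of the two actual numbers. Compound 2 `COc1ncnc2c1c(-c1cc3ccccc3o1)cn2[C@@H]1O[C@H](CO)[C@@H](O)[C@H]1O` stands lower at 22400 nM. Compound 1 `COc1ncnc2c1c(-c1ccccc1)cn2[C@@H]1O[C@H](CO)[C@@H](O)[C@H]1O` gives > 100000 nM, which is a limit of the assay and not a number.

Compound 4 `CSc1ncnc2c1c(-c1ccccc1)cn2[C@@H]1O[C@H](CO)[C@@H](O)[C@H]1O` keeps the core of compound 3 and alters one group: phenyl in place of thiophen-2-yl on an aromatic carbon. In short, it has phenyl in place of thiophen-2-yl on an aromatic carbon. Among the measured compounds shown here, only one measured step touches this place: an at least 4.4-fold lower number from compound 1 to compound 2 (0.64 log units; beyond the scatter), with 1-benzofuran-2-yl in place of phenyl. That step was taken on the core of compound 1, not that of compound 3, and it involves a different incoming group, so it bears on the present change only indirectly. It shows that a swap at this place can move the number in this assay beyond the scatter, but phenyl and thiophen-2-yl have not been compared directly on one core.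

Compound 1, which also carries phenyl, stands at > 100000 nM, again a limit. Compound 4 is therefore expected to stay high, and it may be reported only as a limit. The expected change is a 1.1-fold lower number from compound 3 to compound 4 (0.03 log units; within the scatter), which would be no step beyond the scatter. For compound 4 the estimated value is 90000 nM, with an expected range from 40000 nM to 100000 nM.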

Compound 4, half-maximal inhibitory concentration: > 100000 nM
Compound 4 ended at the assay's limit; the forecaster's own chance of this, stated with the estimate: 50%; at least 1.1-fold (0.04 log units) between middle value and limit.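

In this assay, among the compounds shown here, the core of compound 3 now gives the first direct comparison of phenyl and thiophen-2-yl at this aromatic carbon, and the swap gives an at least 1.0-fold higher number from compound 3 to compound 4 (0.01 log units; that floor lies within the scatter). Going by these compounds, that floor does not establish a real difference between the two groups, and the true size of the step stays unknown, since compound 4 gives > 100000 nM, which is a limit of the assay and not a number. Phenyl now sits at the limit on both the methoxy core of compound 1 and the methylsulfanyl core of compound 4, so the step between these two compounds cannot be read, and neither core yields an actual number with phenyl at this place: the limit of > 100000 nM in this assay, at which 2 of the 4 values shown sit.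

On these data alone, it remains open how far phenyl and thiophen-2-yl really lie apart on the shared core, and whether 1-benzofuran-2-yl would lower the number on the methylsulfanyl core as it does on the methoxy core. Also open, as far as these compounds go, is how an amine or a carboxylic acid at this aromatic carbon would read in this assay.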